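The source may report more compounds than this note shows. Statements on the series, on what has been measured and on what is new or still open speak of the compounds shown alone.

Measured in a functional assay on A2780 cells (Homo sapiens) for inhibition, read by sulforhodamine B assay, with a stated time of 72 h; a higher number here means a weaker inhibitor, a lower number a stronger inhibitor:
- compound 1 `O=C(NCc1ccc(S(=O)(=O)c2ccccc2)cc1)c1nc2cnccc2[nH]1`: 5400 nM
- compound 2 `O=C(NCc1ccc(S(=O)(=O)N2CCCCC2)cc1)c1cc2cnccc2s1`: 1600 nM
- compound 3 `O=C(NCc1ccc(S(=O)(=O)N2CCCCC2)cc1)c1cc2ccncc2[nH]1`: 1700 nM

Compound 1 has the highest number of the three, beyond the scatter from both compound 2 and compound 3. Compound 4 `O=C(NCc1ccc(S(=O)(=O)c2ccccc2)cc1)c1c[nH]c2ccncc12` differs from compound 1 by one change: a group of 9 heavy atoms (7 carbon, 2 nitrogen; one five-membered aromatic ring with 1 hetero atom, one six-membered aromatic ring with 1 hetero atom) in place of a group of 9 heavy atoms (6 carbon, 3 nitrogen; one five-membered aromatic ring with 2 hetero atoms, one six-membered aromatic ring with 1 hetero atom), on a carbonyl carbon. Going by the values given here, no measured step covers this exact swap. The closest is a 1.1-fold higher number from compound 2 to compound 3 (0.03 log units; within the scatter), which also exchanges such a group on a carbonyl carbon, but on a different remainder. That step suggests little sensitivity here, although the data do not show what separates compound 1 from compound 2 and compound 3. In this assay, no step beyond the scatter is expected, with a slight lean towards a lower number. The expected change is a 1.4-fold lower number from compound 1 to compound 4 (0.13 log units; within the scatter). Compound 4 is estimated at 4000 nM, with an expected range of 1500 nM to 9000 nM.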

Compound 4, half-maximal inhibitory concentration: 2100 nM
Estimate against measurement, compound 4: 1.9-fold (0.28 log units) above; low and high end bracket the measured number.
By their numbers in this assay, from the lowest: compounds 2, 3 and 4 (each within the scatter of the next); then compound 1.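

In this assay, the group on the carbonyl carbon matters on the remainder of compound 1: a 2.6-fold lower number from compound 1 to compound 4 (0.41 log units; beyond the scatter). The exchange of such a group on the other remainder, a 1.1-fold higher number from compound 2 to compound 3 (0.03 log units; within the scatter), stays within the scatter, so sensitivity at this place is not uniform across the two remainders. No evidence bears on the origin of this step.

Going by these compounds alone, no pair here carries the same group on the carbonyl carbon on both remainders, so the contribution of the remainder stays open. Also open, from the compounds shown here alone, is how an amine or a methyl group on the group on the carbonyl carbon would affect the number.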